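Removing the last chlorine from the piperazine aryl ring

This account rests on a few compounds, and the source may have more. Where it says the series, first, only, none or still open, it means among the compounds named here.

Measured compounds:
compound 1, `O=C(/C=C/c1ccccc1)c1ccc(N2CCN(c3cccc(Cl)c3)CC2)cc1`: 14.1%
compound 2, `O=C(/C=C/c1ccccc1)c1ccc(N2CCN(c3cccc(Cl)c3Cl)CC2)cc1`: 30.7%
compound 3, `O=C(/C=C/c1ccccc1)c1ccc(N2CCN(c3ccccc3Cl)CC2)cc1`: 4.71%

Three analogues sharing one chalcone-piperazine core have been tested in a functional assay on the whole organism (strain Kunming) for inhibition, with Mus musculus as the target, with a stated time of 1 h, at a dose of 40 mg/kg by the oral route; on this read-out lower numbers stand for less inhibition and higher numbers for more inhibition at the one dose given (going by the name of the read-out). Compound 1 gives 14.1% and compound 2 gives 30.7%; compound 3 gives 4.71%, the lowest of the three numbers, though its nearest neighbour, compound 1, differs from it only by a number 9.4 percentage points lower from compound 1 to compound 3 (within the scatter), which stays within the scatter. The one clear movement among the measured compounds is a number 26 percentage points lower from compound 2 to compound 3 (beyond the scatter), matched in the opposite direction by a number 16.6 percentage points higher from compound 1 to compound 2 (beyond the scatter).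

Compound 4, `O=C(/C=C/c1ccccc1)c1ccc(N2CCN(c3ccccc3)CC2)cc1`, is the next compound to be measured. Its change from compound 3 is hydrogen in place of chloro on an aromatic carbon.

Both measured steps bear on it: each time a chloro is taken from the aromatic ring, this assay reads lower, and each time one is added it reads higher. On that basis a drop would be expected, but compound 3 already sits close to the bottom of the scale, so there is little room to fall. Compound 4 is therefore expected to show a step of a number 0.7 percentage points lower from compound 3 to compound 4 (within the scatter), essentially no movement beyond the scatter. The estimate for compound 4 is 4%, expected to lie between 0% and 16%.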

Compound 4, a percentage reported as inhibition, in the whole organism at one dose (the size of the read-out at that dose, not a potency): 3.71%
The estimate for compound 4 lay 0.3 percentage points above the measured number; the measured number falls inside the stated range.
By their numbers in this assay, from the lowest: compounds 4, 3 and 1 (each within the scatter of the next, the first and the last beyond it); then compound 2.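

In this assay, the change from 2-chlorophenyl to phenyl gives a number 1 percentage points lower from compound 3 to compound 4 (within the scatter), so on a ring with no other chloro, the chloro ortho to a large group has no effect that can be read. The same exchange of hydrogen for chloro in the other place gives a number 10.4 percentage points lower from compound 1 to compound 4 (beyond the scatter), and the full change from 2,3-dichlorophenyl to phenyl gives a number 27 percentage points lower from compound 2 to compound 4 (beyond the scatter), so among these compounds only the rings with a chloro outside that place stand clear of the unsubstituted phenyl of compound 4. What a chloro ortho to a large group adds therefore depends on what else the ring carries: the same change on two cores in this assay, a number 16.6 percentage points higher (beyond the scatter) from compound 1 to compound 2 and a number 1 percentage points higher (within the scatter) from compound 4 to compound 3, 15.6 percentage points apart, beyond the scatter of two such steps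

The compounds shown leave open whether this dependence belongs to chlorine itself, since none carries a fluoro, methyl or methoxy group on this ring. Among the compounds shown here, they also leave open how the low readings of compound 4, compound 3 and compound 1 would compare at other doses or times, since each has only a single reading at one dose.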